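Readings at the Limit and a Side-Chain Swap

The source may report more compounds than this note shows. Statements on the series, on what has been measured and on what is new or still open speak of the compounds shown alone.

Of the compounds shown here, three have been read so far in a functional assay on HGC-27 cells (Homo sapiens) for inhibition, read by MTT assay, with a stated time of 72 h; on this read-out lower numbers stand for stronger inhibition and higher numbers for weaker inhibition. Compound 1 (`Cc1nc2nc(SCc3ccc(Cl)cc3)nn2c(N2CC[C@@H](C)[C@@H](N(C)c3ncnc4[nH]ccc34)C2)c1C`) gives > 100000 nM, which is a limit and not a number. Compound 2 (`Cc1cc(N2CC[C@@H](C)[C@@H](N(C)c3ncnc4[nH]ccc34)C2)n2nc(SCc3csc4ccc(Cl)cc34)nc2n1`) gives > 100000 nM, which is also a limit. Compound 3 (`CCCCCc1c(C)nc2nc(SCc3ccc(Cl)cc3)nn2c1N1CC[C@@H](C)[C@@H](N(C)c2ncnc3[nH]ccc23)C1`) gives > 100000 nM, again a limit. Compound 2 therefore has no numerical standing of its own, and the whole set comes down to the limit of > 100000 nM in this assay, at which 3 of the 3 values shown sit.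

Compound 4 (`COc1ccc(CSc2nc3nc(C)cc(N4CC[C@@H](C)[C@@H](N(C)c5ncnc6[nH]ccc56)C4)n3n2)cc1`) is the next to be read. It departs from compound 2 as follows: 4-methoxyphenyl in place of 5-chloro-1-benzothiophen-3-yl on a saturated chain carbon bound to a sulfur. In short, 4-methoxyphenyl stands in place of 5-chloro-1-benzothiophen-3-yl on a saturated chain carbon bound to a sulfur.

For the measured compounds named here, the one measured step is a step that the two limits leave unreadable from compound 1 to compound 3. It places butyl in place of hydrogen on a saturated chain carbon bound to an aromatic carbon, elsewhere in the structure, and it offers no size to carry over. No step beyond the scatter is therefore expected in this assay. Because compound 2 sits at the limit > 100000 nM, compound 4 is expected to read at that same limit. The expected change is a number no higher from compound 2 to compound 4 (the limit leaves the size open). For compound 4 the estimate is 100000 nM, with an expected range from 30000 nM to 200000 nM.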

Compound 4, half-maximal inhibitory concentration: 18200 nM
Beside the measured number, compound 4's estimate is 5.5-fold (0.74 log units) above it; the whole stated range lies above it.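

In this assay, for the compounds shown here, the series now holds its only reading that is a number and not a limit, and the change on a saturated chain carbon bound to a sulfur, 4-methoxyphenyl in place of 5-chloro-1-benzothiophen-3-yl, gives an at least 5.4-fold lower number from compound 2 to compound 4 (0.73 log units; beyond the scatter). Going by these compounds alone, the earlier compounds offered limits alone and their one step cannot be read, so this is the first evidence in the notes that the group at this place can move the read-out. Compound 2 stands at a limit and not a number, so the step carries only a minimum size, and the set as a whole still rests on that same ceiling: the limit of > 100000 nM in this assay, at which 3 of the 4 values shown sit.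

From the compounds shown here alone, how a plain phenyl or a 4-ethoxyphenyl reads on the same carbon stays open, so the step cannot yet be divided between the methoxy group that enters and the 5-chloro-1-benzothiophen-3-yl that leaves. Also open, going by these compounds, is whether a number survives when 4-methoxyphenyl is paired with a butyl chain on the core, or whether a terminal amine or carboxylic acid on that group shifts the read-out further.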